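The compounds below may be only part of what the source reports. "The series", "measured", "known", "first", "only" and "open" are said of these compounds alone.

Measured compounds in the series:
- compound 1 `NC(=O)c1cn(-c2ccc(O)c(Cl)c2)c2cc(-c3ccncc3)ccc2c1=O`: 2000 nM
- compound 2 `NC(=O)c1cn(-c2ccc(O)cc2Cl)c2cc(-n3cccn3)ccc2c1=O`: 600 nM
- compound 3 `NC(=O)c1cn(-c2ccc(O)cc2Cl)c2cc(-c3ccoc3)ccc2c1=O`: 2000 nM

All three values come from an assay on isolated protein for inhibition of Calpain-1 catalytic subunit (Homo sapiens); a higher number here means a weaker inhibitor, a lower number a stronger inhibitor. Going by the values given here, compound 3 sits level with compound 1 at the digits recorded, the two together giving the highest numbers of the set; its only single-site neighbour is compound 2, and the step from that compound is a 3.3-fold higher number from compound 2 to compound 3 (0.52 log units; beyond the scatter).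

The next compound, compound 4 `NC(=O)c1cn(-c2ccc(O)cc2Cl)c2cc(-c3ccncc3Cl)ccc2c1=O`, is reached from compound 3 by one change: 3-chloropyridin-4-yl in place of furan-3-yl on an aromatic carbon. Among the compounds with values here, no measured step swaps a five-membered ring for a six-membered one at this position, so the only step that bears on it is a 3.3-fold higher number from compound 2 to compound 3 (0.52 log units; beyond the scatter), which shows that a change of ring at this site can move the number by a modest amount. Compound 1 carries pyridin-4-yl at the same position but also differs in the placement of chlorine on the hydroxyphenyl group, so its value of 2000 nM can only be read loosely as a pointer; it lies at the same number as compound 3.

On that basis the step of a 1.3-fold lower number from compound 3 to compound 4 (0.12 log units; within the scatter) is expected to stay small, with wide uncertainty. The estimate for compound 4 in this assay is 1500 nM, with a range from 400 nM to 6000 nM.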

Compound 4, half-maximal inhibitory concentration: 2000 nM
The estimate for compound 4 lay 1.3-fold (0.12 log units) below the measured number; the range from low to high includes it.
By their numbers in this assay, from the lowest: compound 2; then compounds 1, 3 and 4 (each within the scatter of the next).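

In this assay, the position meta to a fused ring takes the larger six-membered 3-chloropyridin-4-yl in place of the five-membered furan-3-yl with no change at the digits printed from compound 3 to compound 4 (within the scatter), so in this pair neither ring size nor the larger group moves the number. Going by these compounds alone, the reading against 1H-pyrazol-1-yl is now repeated with a second group, a 3.3-fold higher number from compound 2 to compound 4 (0.52 log units; beyond the scatter), which leaves compound 2 as the only one of the three single-site neighbours with the lower number, and 1H-pyrazol-1-yl as the only group of the three joined through a ring nitrogen, although three compounds cannot tie the lower number to that feature. Nothing measured on these compounds accounts for the level readings of furan-3-yl and 3-chloropyridin-4-yl or for the gap to 1H-pyrazol-1-yl.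

From the compounds shown here alone, it remains open what the chlorine of 3-chloropyridin-4-yl contributes on its own, and whether other five-membered rings joined through nitrogen, such as imidazol-1-yl, follow 1H-pyrazol-1-yl or furan-3-yl. Also open, going by these compounds, is how a non-aromatic group at this position, such as an amine like morpholine or a carboxylic acid, would read in this assay against these aromatic rings.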